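Swapping the Aryl Group for Thiophene in an Acrylamide Series

This account rests on a few compounds, and the source may have more. Where it says the series, first, only, none or still open, it means among the compounds named here.

Three compounds share one core and differ only in the aromatic group on a saturated ring carbon. Compound 1 `C=CC(=O)N1C(=O)CC(c2cccc(Cl)c2)Sc2ccccc21` carries a 3-chlorophenyl group there; in a functional assay on HL-60 cells (Homo sapiens) for cytotoxicity, read by CCK-8 assay, with a stated time of 24 h (a lower number here means a stronger inhibitor, a higher number a weaker inhibitor), compound 1 gives 93100 nM. Compound 2 `C=CC(=O)N1C(=O)CC(c2ccc(C(=O)OC)cc2)Sc2ccccc21` carries a methoxycarbonyl-substituted phenyl and gives 102000 nM, while compound 3 `C=CC(=O)N1C(=O)CC(c2ccc(C(F)(F)F)cc2)Sc2ccccc21` carries a trifluoromethyl-substituted phenyl and gives 106000 nM. All three numbers lie within the usual scatter of one another, so none can be called stronger or weaker; compound 1 simply sits at the lower end of this narrow band.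

Compound 4 `C=CC(=O)N1C(=O)CC(c2cccs2)Sc2ccccc21` is the next step from compound 1: thiophen-2-yl in place of 3-chlorophenyl on a saturated ring carbon. Going by the values given here, the only measured step at this position, a 1.0-fold higher number from compound 2 to compound 3 (0.02 log units; within the scatter), changed nothing beyond the scatter, and the numbers for compound 1, compound 2 and compound 3 show that exchanging one substituted phenyl for another left this assay essentially unmoved. Among the compounds with values here, no measured pair exchanges a phenyl for a five-membered heteroaromatic ring, so the new thiophen-2-yl is untested here.

On that basis compound 4 is expected to behave like its neighbours, with the step of a 1.1-fold higher number from compound 1 to compound 4 (0.03 log units; within the scatter) estimated to fall within the scatter. The estimate for compound 4 is 100000 nM, with a range from 50000 nM to 200000 nM.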

Compound 4, half-maximal inhibitory concentration: 695000 nM
Compound 4: middle estimate off by 7.0-fold (0.84 log units), on the low side; measured number above the stated range.
By their numbers in this assay, from the lowest: compounds 1, 2 and 3 (each within the scatter of the next); then compound 4.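

In this assay, going by these compounds alone, the step of a 7.5-fold higher number from compound 1 to compound 4 (0.87 log units; beyond the scatter) is the first change that lies beyond the scatter, and it moves toward weaker inhibition. The group on this saturated ring carbon therefore matters more than the closely grouped values of compound 1, compound 2 and compound 3 suggested, since their band of substituted phenyl groups does not extend to thiophen-2-yl. No measurement available here accounts for the change, and this single step replaces both the six-membered carbon ring and its chlorine, so it cannot assign the shift to either one.

An unsubstituted phenyl group on the same carbon would help separate these two parts of the change, by showing what the chlorine contributes without any change of ring. Furan-2-yl, thiophen-3-yl or a thiophen-2-yl ring bearing chlorine would show whether the higher number follows the five-membered ring in general, the ring sulfur, or the point at which the ring is attached.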